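Nitrophenyl Replaces Difluorophenyl: Cytotoxicity Outlook for Compound 3

The source may report more compounds than this note shows. Statements on the series, on what has been measured and on what is new or still open speak of the compounds shown alone.

Compound 2 `Cc1cc(=O)oc2cc(OCc3cn(-c4ccc(F)cc4F)nn3)ccc12` gives > 100 ug/mL in an ADME assay on Huh-7 cells (Homo sapiens) for cytotoxicity, read by MTT assay, with a stated time of 72 h (on this read-out lower numbers stand for higher toxicity in this test and higher numbers for lower toxicity in this test), which is a limit of the test rather than a number. Compound 1 `Cc1cc(=O)oc2cc(OCc3cn(-c4ccccc4Cl)nn3)ccc12` likewise sits at a limit in this assay, with > 100 ug/mL. The step that the two limits leave unreadable from compound 1 to compound 2 cannot be read, since (the limit of > 100 ug/mL in this assay, at which 2 of the 2 values shown sit). Compound 3 `Cc1cc(=O)oc2cc(OCc3cn(-c4ccccc4[N+](=O)[O-])nn3)ccc12` differs from compound 2 by 2-nitrophenyl in place of 2,4-difluorophenyl on an aromatic nitrogen. Within the data shown here, with both measured values resting at the limit, no measured step gives a direction, and no step beyond the scatter is expected a step that the limit leaves unreadable from compound 2 to compound 3. Compound 3 is therefore expected to give 150 ug/mL, within 60 ug/mL to 400 ug/mL, most likely reported again only as a limit.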

Compound 3, half-maximal cytotoxic concentration: > 100 ug/mL
Compound 3: no number, only a limit; the forecaster's own chance of this, stated with the estimate: 75%; the middle value lies beyond the limit too.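

In this assay no step can be read among compound 1, compound 2 and compound 3, as all three rest at a limit: the limit of > 100 ug/mL in this assay, at which 3 of the 3 values shown sit.

The compounds shown leave open whether 2-chlorophenyl, 2,4-difluorophenyl and 2-nitrophenyl differ at all in cytotoxicity.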